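This account rests on a few compounds, and the source may have more. Where it says the series, first, only, none or still open, it means among the compounds named here.

Compound 1 `CCNC(=O)c1cc(-c2cnn3cc(-c4cnn(C)c4)cnc23)cs1` gives 129 nM in an assay for inhibition of MAP/microtubule affinity-regulating kinase 3 (Homo sapiens), read by HTRF, with a stated time of 2 h (a lower number here means a stronger inhibitor, a higher number a weaker inhibitor), the highest number among the values given here. Compound 3 `Cn1cc(-c2cnc3c(-c4csc(C(=O)N[C@@H]5CCCC[C@@H]5O)c4)cnn3c2)cn1` gives 9 nM in this assay. Compound 2 `Cn1cc(-c2cnc3c(-c4csc(C(=O)N[C@@H]5CCCC[C@@H]5N)c4)cnn3c2)cn1` reaches only a limit of this assay, <= 0.5 nM. Compound 4 `Cn1cc(-c2cnc3c(-c4csc(C(=O)N[C@@H]5CCC[C@H]5N)c4)cnn3c2)cn1` carries a group of 6 heavy atoms (5 carbon, 1 nitrogen; one five-membered non-aromatic ring of carbon only) in place of a group of 2 heavy atoms (2 carbon; no ring), on an amide-type nitrogen. The measured steps that bear on this change are an at least 250-fold lower number from compound 1 to compound 2 (2.41 log units; beyond the scatter) and a 14-fold lower number from compound 1 to compound 3 (1.16 log units; beyond the scatter), both large. The amino-bearing ring of compound 2 sits at the limit of <= 0.5 nM in this assay, at which 1 of the 3 values shown sits. Replacing amino by hydroxy gave an at least 18-fold higher number from compound 2 to compound 3 (1.25 log units; beyond the scatter). Since compound 4 keeps the amino group on a five-membered non-aromatic ring, a large downward step is expected, a 130-fold lower number from compound 1 to compound 4 (2.11 log units; beyond the scatter). Compound 4 is therefore estimated at 1 nM, within a range from 0.3 nM to 5 nM, and the result may again be only a limit.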

Compound 4, half-maximal inhibitory concentration: 3 nM
For compound 4 the middle estimate is 3.0-fold (0.48 log units) below the measured one; the range from low to high includes it.
By their numbers in this assay, from the lowest: compound 4; then compound 3; then compound 1. At a limit, below all of these: compound 2.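

With an amino-bearing five-membered ring on the amide-type nitrogen, the large gain over ethyl remains, a 43-fold lower number from compound 1 to compound 4 (1.63 log units; beyond the scatter), so that gain does not require the six-membered ring of compound 2. Ring size and the group on the ring change together in a 3.0-fold lower number from compound 3 to compound 4 (0.48 log units; beyond the scatter), so this step cannot be credited to either alone. The step of an at least 6.0-fold higher number from compound 2 to compound 4 (0.77 log units; beyond the scatter) is beyond the scatter, but its size is only a bound, with compound 2 at a limit: the limit of <= 0.5 nM in this assay, at which 1 of the 4 values shown sits.

On these data alone, whether an open-chain 2-aminoethyl group, with no ring, would keep the gain stays open. So does how a hydroxy group would fare on the five-membered ring.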